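This account rests on a few compounds, and the source may have more. Where it says the series, first, only, none or still open, it means among the compounds named here.

Measured in a functional assay on NCI-H226 cells (Homo sapiens) for cytotoxicity, read by sulforhodamine B assay, with a stated time of 48 h; on this read-out lower numbers stand for higher toxicity in this test and higher numbers for lower toxicity in this test:
compound 1, `ClCc1ccccc1Cn1cnc2c(Cl)nc(Cl)nc21`: 6760 nM
compound 2, `ClCc1ccccc1Cn1cnc2c(Cl)ncnc21`: 38900 nM
compound 3, `ClCc1cccc(Cn2cnc3ncnc(Cl)c32)c1`: 9330 nM

Compounds 1 and 2 share a core and differ in a single place: chloro in place of hydrogen on an aromatic carbon. In this assay that change gave a 5.8-fold lower number from compound 2 to compound 1 (0.76 log units; beyond the scatter). Compound 3 has the same atoms as compound 2 joined differently; the difference between the two cores is not broken down here. In this assay compound 3 sits close to compound 1 and clearly apart from compound 2.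

Compound 4, `ClCc1cccc(Cn2cnc3nc(Cl)nc(Cl)c32)c1`, is not yet measured. It stands to compound 3 as compound 1 stands to compound 2: chloro in place of hydrogen on an aromatic carbon. The two place descriptions read the same word for word, so this is the same change on a differently joined core. Within the data shown here, a step of roughly the size already seen is expected, resting on compound 3 at 9330 nM and on a 5.8-fold lower number from compound 2 to compound 1 (0.76 log units; beyond the scatter); the single precedent leaves room for a smaller or larger effect. The step from compound 3 to compound 4 is expected to be a 4.7-fold lower number from compound 3 to compound 4 (0.67 log units; beyond the scatter) in this assay. Compound 4 is estimated at 2000 nM in this assay, with an expected range from 800 nM to 6000 nM.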

Compound 4, concentration lethal to 50% of the cells: 20000 nM
The estimate for compound 4 lay 10-fold (1.00 log units) below the measured number, outside the stated range (above it).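

Chloro in place of hydrogen on an aromatic carbon gave a 2.1-fold higher number from compound 3 to compound 4 (0.33 log units; beyond the scatter) in this assay, so the direction seen on the other core was not kept. Set side by side, the two steps differ, and for these two pairs the outcome of the same change depends on the core that carries it: the same change on two cores in this assay, a 5.8-fold lower number (0.76 log units; beyond the scatter) from compound 2 to compound 1 and a 2.1-fold higher number (0.33 log units; beyond the scatter) from compound 3 to compound 4, 12-fold (1.09 log units) apart, beyond the scatter of two such steps

This does not show which difference between the two cores lies behind the split, and two pairs give no rule for any further core in the series.

Still open, going by these compounds, is how an amine or a methoxy group would behave in the same place, between two ring nitrogen atoms, and whether either would track the chloro step on one core, on both or on neither. Also open, on these data alone, is whether the split between the two cores would hold in a cell line other than this one.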